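Shifting a Fluorine on the Ring Bound to the Carbonyl

This account rests on a few compounds, and the source may have more. Where it says the series, first, only, none or still open, it means among the compounds named here.

Compound 2 `O=C(NCc1ccc(CNS(=O)(=O)c2ccccc2)cc1)c1cccc(F)c1` has been measured in an assay on MDA-MB-231 cells for binding affinity to C-X-C chemokine receptor type 4 (Homo sapiens), read by immunofluorescence and microscopy, with stated times of 10 min and 30 min (a lower number here means that less compound is needed, a higher number that more compound is needed for the effect), where compound 2 gives 100 nM. Its nearest neighbour is compound 1 `O=C(NCc1ccc(CNS(=O)(=O)c2ccccc2)cc1)c1ccc(Cl)cc1`, which in this assay gives 100 nM; the step of no change at the digits printed from compound 1 to compound 2 (within the scatter) stayed within the scatter, so compound 2 stands level with compound 1 at the digits shown.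

Compound 3 `O=C(NCc1ccc(CNS(=O)(=O)c2ccccc2)cc1)c1ccccc1F` differs from compound 2 by 2-fluorophenyl in place of 3-fluorophenyl on a carbonyl carbon. Among the compounds with values here, only one measured step bears on this: no change at the digits printed from compound 1 to compound 2 (within the scatter), in which one halogen-bearing phenyl replaced another on the same carbonyl carbon and nothing moved beyond the scatter. That step exchanged one ring for a differently substituted one rather than moving a fluorine within the same ring, so it speaks only indirectly to compound 3. The expectation is therefore a small step, a 1.5-fold higher number from compound 2 to compound 3 (0.18 log units; within the scatter), with no firm direction. Compound 3 is estimated at 150 nM, within a range from 50 nM to 500 nM.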

Compound 3, effective concentration (reported as EC, without a stated level of effect): 1000 nM
The estimate for compound 3 lay 6.7-fold (0.82 log units) below the measured number; the whole stated range lies below it.
By their numbers in this assay, from the lowest: compounds 1 and 2 (each within the scatter of the next); then compound 3.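

In this assay the place of the fluorine matters: with the same atoms joined differently, 2-fluorophenyl in place of 3-fluorophenyl on the carbonyl carbon gives a 10-fold higher number from compound 2 to compound 3 (1.00 log units; beyond the scatter). Set against the 4-chlorophenyl ring, the same group gives a 10-fold higher number from compound 1 to compound 3 (1.00 log units; beyond the scatter), whereas the earlier exchange showed no change at the digits printed from compound 1 to compound 2 (within the scatter), so this position is not indifferent to which substituted phenyl it carries. Nothing in the data accounts for this step.

On these data alone, whether a 2-chlorophenyl or 2-methylphenyl on the carbonyl carbon would follow compound 3, or instead stand with compound 1 and compound 2, remains open. So does whether an unsubstituted phenyl, or a phenyl bearing an amine or a carboxylic acid, would keep the lower number in this assay.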